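The source may report more compounds than this note shows. Statements on the series, on what has been measured and on what is new or still open speak of the compounds shown alone.

Measured in a functional assay on SK-OV-3 cells (Homo sapiens) for cytotoxicity; a higher number here means a weaker inhibitor, a lower number a stronger inhibitor:

compound 1 `O=C(CCCCCCc1nc2ccc(-c3ccccc3)cc2[nH]1)NO` — 100 nM
compound 2 `O=C(CCCCCCc1nc2ccc(-c3ccc(F)cc3)cc2[nH]1)NO` — 1200 nM
compound 3 `O=C(CCCCCCc1nc2cccc(Cl)c2[nH]1)NO` — 10000 nM

Compound 2 stands second highest of the three numbers in this assay: compound 3 gives a higher number and compound 1 a lower one, each gap beyond the scatter. For the measured compounds named here, the single one-place step among the measured compounds, a 12-fold higher number from compound 1 to compound 2 (1.08 log units; beyond the scatter), shows a large loss on adding fluoro to the aromatic carbon.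

Compound 4 `CN(C)c1ccc2nc(CCCCCCC(=O)NO)[nH]c2c1` differs from compound 2 as follows: dimethylamino in place of 4-fluorophenyl on an aromatic carbon. Going by the values given here, no measured step covers this exchange directly; the step of a 12-fold higher number from compound 1 to compound 2 (1.08 log units; beyond the scatter) concerns only the fluoro and says nothing about removing the whole 4-fluorophenyl. Compound 3, which carries no aryl group on the shared core, gives the highest number of the set, but it differs from compound 2 in more than one place, so its value is only a loose pointer. A moderate step toward a higher number is therefore expected for compound 4, a 2.1-fold higher number from compound 2 to compound 4 (0.32 log units; beyond the scatter), with wide uncertainty. Compound 4 is estimated at 2500 nM, within 600 nM to 10000 nM.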

Compound 4, half-maximal inhibitory concentration: 1200 nM
For compound 4 the middle estimate is 2.1-fold (0.32 log units) above the measured one; the measured number falls inside the stated range.
By their numbers in this assay, from the lowest: compound 1; then compounds 2 and 4 (each within the scatter of the next); then compound 3.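

In this assay the exchange of 4-fluorophenyl for dimethylamino gives no change at the digits printed from compound 2 to compound 4 (within the scatter), so at this aromatic carbon a group with no ring matches the 4-fluorophenyl group, and an aromatic ring is not needed to reach that level. Set against the unsubstituted phenyl group, dimethylamino gives a 12-fold higher number from compound 1 to compound 4 (1.08 log units; beyond the scatter), a step that reads the same as a 12-fold higher number from compound 1 to compound 2 (1.08 log units; beyond the scatter), which leaves phenyl apart from both replacements in this pair of one-place steps. Nothing available on these compounds bears on why the steps take these sizes.

On these data alone, it remains open whether the low number of compound 1 is specific to phenyl or would carry over to a pyridyl ring or a 4-methoxyphenyl group at this carbon. Also open, as far as these compounds go, is how a smaller amine such as a primary amine, or a carboxylic acid, would compare with dimethylamino here.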